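Predicting a 3,5-dimethoxybenzyl analogue from a measured pair

The compounds below may be only part of what the source reports. "The series", "measured", "known", "first", "only" and "open" are said of these compounds alone.

Measured so far:
compound 1 `COc1ccc(Cn2cc(CNC(=O)c3cn(-c4ccccc4)nc3-c3ccccc3)nn2)cc1OC`: 8200 nM
compound 2 `COc1cc(Cn2cc(CNC(=O)c3cn(-c4ccccc4)nc3-c3ccccc3)nn2)cc(OC)c1`: 190 nM
compound 3 `COc1ccc(-c2nn(-c3ccccc3)cc2C(=O)NCc2cn(Cc3ccc(OC)c(OC)c3)nn2)cc1`: 16300 nM

All three were tested in a functional assay on MIA PaCa-2 cells (Homo sapiens) for antiproliferative activity, read by sulforhodamine B assay, with a stated time of 48 h; on this read-out higher numbers stand for weaker inhibition of growth and lower numbers for stronger inhibition of growth. Compound 4 `COc1ccc(-c2nn(-c3ccccc3)cc2C(=O)NCc2cn(Cc3cc(OC)cc(OC)c3)nn2)cc1` has not been measured yet. Compound 4 stands to compound 3 as compound 2 stands to compound 1: the change is 3,5-dimethoxyphenyl in place of 3,4-dimethoxyphenyl on a saturated chain carbon bound to an aromatic nitrogen and, in the measured pair, (3,5-dimethoxyphenyl in place of 3,4-dimethoxyphenyl on a saturated chain carbon bound to an aromatic nitrogen). The two cores differ by methoxy in place of hydrogen on an aromatic carbon, a step of a 2.0-fold higher number from compound 1 to compound 3 (0.30 log units; within the scatter), so compound 3 behaves much like compound 1. The measured step was a 43-fold lower number from compound 1 to compound 2 (1.64 log units; beyond the scatter), a large gain. Because compound 1 and compound 3 differ only by a 2.0-fold higher number from compound 1 to compound 3 (0.30 log units; within the scatter), the same change is expected to give compound 4 a step of about a 36-fold lower number from compound 3 to compound 4 (1.56 log units; beyond the scatter), a little smaller than the measured one to allow for uncertainty. Compound 4 is therefore estimated at 450 nM, with a range from 120 nM to 2500 nM.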

Compound 4, concentration for 50% growth inhibition: 5800 nM
Compound 4: middle estimate off by 13-fold (1.11 log units), on the low side; measured number outside the range, above it.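

In this assay, the 3,5-dimethoxybenzyl group in place of 3,4-dimethoxybenzyl still lowers the number on the methoxy-bearing core, with a 2.8-fold lower number from compound 3 to compound 4 (0.45 log units; beyond the scatter), so the direction carries over but the size does not: the same change on two cores in this assay, a 43-fold lower number (1.64 log units; beyond the scatter) from compound 1 to compound 2 and a 2.8-fold lower number (0.45 log units; beyond the scatter) from compound 3 to compound 4, 15-fold (1.19 log units) apart, beyond the scatter of two such steps

Likewise, methoxy in place of hydrogen on an aromatic carbon matters far more when the 3,5-dimethoxybenzyl group is present, with a 31-fold higher number from compound 2 to compound 4 (1.48 log units; beyond the scatter), so the two changes do not simply add up: the same change on two cores in this assay, a 2.0-fold higher number (0.30 log units; within the scatter) from compound 1 to compound 3 and a 31-fold higher number (1.48 log units; beyond the scatter) from compound 2 to compound 4, 15-fold (1.19 log units) apart, beyond the scatter of two such steps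

This shows that the gain seen on one core cannot be carried at full size to the other, but two pairs do not show why, or how the change would behave on any further core.

As far as these compounds go, it remains open whether a fluorine or a hydroxyl in place of that methoxy would keep the large gain. From the compounds shown here alone, the behaviour of a plain benzyl group on either core also remains open.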